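A few compounds are considered here, and "the series" means these few. Any claim that something is new, unique, unknown or untested is made for them only; others in the source may bear on it.

In a functional assay on HCT-116 cells (Homo sapiens) for inhibition, read by MTT assay, with a stated time of 48 h (on this read-out higher numbers stand for weaker inhibition and lower numbers for stronger inhibition), compound 1 `COc1ccc(-n2c(SCc3ccccc3)nnc2-c2cc(OC)c(OC)c(OC)c2)cc1` gives 42400 nM and compound 2 `COc1ccc(CSc2nnc(-c3cc(OC)c(OC)c(OC)c3)n2-c2ccc(OC)cc2)cc1` gives 49600 nM. Among the measured compounds shown here, these are the only two numbers, and they cannot be told apart: a 1.2-fold higher number from compound 1 to compound 2 (0.07 log units; within the scatter). Compound 3 `COc1ccc(-n2c(SCC(=O)Nc3ccc(Cl)cc3)nnc2-c2cc(OC)c(OC)c(OC)c2)cc1` is reported only as a limit, > 60000 nM.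

Compound 4 `COc1ccc(CSc2nnc(-c3cc(OC)c(OC)c(OC)c3)n2-c2ccc(N(C)C)cc2)cc1` differs from compound 2 in one place, with dimethylamino in place of methoxy on an aromatic carbon, para to a large group, turning 4-methoxyphenyl into 4-(dimethylamino)phenyl: dimethylamino in place of methoxy on an aromatic carbon.

For the measured compounds named here, no measured step touches this position. The nearest in kind is the methoxy-for-hydrogen exchange on another aromatic ring, a 1.2-fold higher number from compound 1 to compound 2 (0.07 log units; within the scatter). The other two steps alter the group on the chain bound to sulfur: an at least 1.4-fold higher number from compound 1 to compound 3 (0.15 log units; that floor lies within the scatter) and an at least 1.2-fold higher number from compound 2 to compound 3 (0.08 log units; that floor lies within the scatter). None of these gives grounds to expect a real shift in this assay, so the expected change is a 1.2-fold lower number from compound 2 to compound 4 (0.09 log units; within the scatter), with no direction beyond the scatter. For compound 4 the estimated value is 40000 nM, with an expected range of 15000 nM to 70000 nM.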

Compound 4, half-maximal inhibitory concentration: 1150 nM
Compound 4: middle estimate off by 35-fold (1.54 log units), on the high side; measured number outside the range, below it.
By their numbers in this assay, from the lowest: compound 4; then compounds 1 and 2 (each within the scatter of the next). At a limit, above all of these: compound 3.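

In this assay, among the compounds shown here, exchanging methoxy for dimethylamino on an aromatic carbon, para to a large group, gives a 43-fold lower number from compound 2 to compound 4 (1.63 log units; beyond the scatter), and this is the first step with a size printed beyond the scatter. Compounds 1, 2 and 3 all carry 4-methoxyphenyl here, so they could not show that this position responds, while their changes elsewhere gave no readable shift. The exchange is small in what is counted, with one more heavy atom and the same hydrogen-bond donor and acceptor counts, and nothing shown accounts for the size of the step.

On these data alone, whether the effect is particular to dimethylamino remains open, as a primary amine, diethylamino or plain hydrogen at this position would test that. Also open, as far as these compounds go, is whether 4-(dimethylamino)phenyl has the same effect alongside the unsubstituted benzyl on sulfur of compound 1.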